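Carbonyl substituent change on compound 1

This account rests on a few compounds, and the source may have more. Where it says the series, first, only, none or still open, it means among the compounds named here.

Within the data shown here, in a functional assay on HCT-116 cells (Homo sapiens) for antiproliferative activity, read by sulforhodamine B assay, with a stated time of 72 h (on this read-out higher numbers stand for weaker inhibition and lower numbers for stronger inhibition), compound 1 `CCOC(=O)c1cnc2ccc(-c3cnc(OC)c(NS(=O)(=O)c4ccc(F)cc4F)c3)cn12` gives 90 nM, the lowest number measured so far. Compound 2 `CCOC(=O)c1cnc2ccc(-c3cnc(OC)c(NS(=O)(=O)c4ccc(F)cc4)c3)cn12` gives 640 nM, and compound 3 `CCCCS(=O)(=O)Nc1cc(-c2ccc3ncc(C(=O)OCC)n3c2)cnc1OC` gives 4940 nM. Compound 4 `COc1ncc(-c2ccc3ncc(C(=O)N4CCC(O)CC4)n3c2)cc1NS(=O)(=O)c1ccc(F)cc1F` is still unmeasured and departs from compound 1 on a carbonyl carbon: 4-hydroxypiperidin-1-yl in place of ethoxy on a carbonyl carbon. The measured steps, a 7.1-fold higher number from compound 1 to compound 2 (0.85 log units; beyond the scatter), a 55-fold higher number from compound 1 to compound 3 (1.74 log units; beyond the scatter) and a 7.7-fold higher number from compound 2 to compound 3 (0.89 log units; beyond the scatter), all alter the sulfonyl substituent and none alters the carbonyl substituent, so they bear on this change only indirectly. They show that the numbers in this series can move, not how far they move at this place. The expected step, held loosely, is a 2.8-fold higher number from compound 1 to compound 4 (0.44 log units; beyond the scatter), toward weaker inhibition. Compound 4 is estimated at 250 nM, with a range of 50 nM to 1200 nM.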

Compound 4, half-maximal inhibitory concentration: 490 nM
Compound 4: the middle estimate sits 2.0-fold (0.29 log units) below what was measured; low and high end bracket the measured number.
By their numbers in this assay, from the lowest: compound 1; then compounds 4 and 2 (each within the scatter of the next); then compound 3.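

The carbonyl substituent now has its first direct reading: in this assay, the change from ethoxy to 4-hydroxypiperidin-1-yl gives a 5.4-fold higher number from compound 1 to compound 4 (0.74 log units; beyond the scatter), so this place also moves the numbers. The step is smaller than the butyl change on the sulfonyl sulfur of compound 1, a 55-fold higher number from compound 1 to compound 3 (1.74 log units; beyond the scatter). Nothing available explains the size of the carbonyl step.

As far as these compounds go, how a plain piperidin-1-yl, a morpholin-4-yl or a carboxylic acid would read at this carbonyl carbon remains open, as does whether the hydroxyl or the ring goes with the step. Also open, from the compounds shown here alone, is whether the step holds with 4-fluorophenyl or butyl on the sulfonyl sulfur.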